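This account rests on a few compounds, and the source may have more. Where it says the series, first, only, none or still open, it means among the compounds named here.

Measured in a functional assay on L02 cells (Homo sapiens) for inhibition, read by Griess assay, with stated times of 1 h and 24 h; a lower number here means a stronger inhibitor, a higher number a weaker inhibitor:
Compound 1 `CCCc1nn(C)c2c(NCc3ccc(F)cc3)nc(CCc3cccnc3)nc12`: compound 1 gives < 40000 nM, which is a limit of the assay.
Compound 2 `COc1ccc(Nc2nc(/C=C/c3ccccc3)nc3ccsc23)cc1`: compound 2 gives > 1000000 nM, which is a limit of the assay.
Compound 3 `COc1cc(/C=C/c2nc(NC3CC3)c3sccc3n2)cc(OC)c1OC`: compound 3 gives > 1000000 nM, which is a limit of the assay.

None of the three compounds has a measured number; each sits at a limit. Compound 3 stands at the limit of > 1000000 nM in this assay, at which 2 of the 3 values shown sit, the weaker end of what is reported, and compound 1 alone reaches (the limit of < 40000 nM in this assay, at which 1 of the 3 values shown sits). Compound 4 `COc1cc(/C=C/c2nc(Nc3ccc(O)cc3)c3sccc3n2)cc(OC)c1OC` is built from compound 3 by one change: 4-hydroxyphenyl in place of cyclopropyl on a nitrogen on an aromatic ring, cut one bond further out, cyclopropylamino to (4-hydroxyphenyl)amino. Within the data shown here, no step between two measured compounds is available, so the size of this change in this assay cannot be read from the data. The nearest comparison is compound 2, which also carries an arylamino group beside a styryl group and likewise sits at a limit. On that basis the expected step from compound 3 to compound 4 is a number no higher from compound 3 to compound 4 (the limit leaves the size open), nothing beyond the scatter. Compound 4 is therefore estimated at 1000000 nM, with a range from 300000 nM to 3000000 nM, and most likely only a limit will be reported again.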

Compound 4, half-maximal inhibitory concentration: > 1000000 nM
Compound 4: a limit, no number; the forecaster's own chance of this, stated with the estimate: 75%; the middle value sits exactly at the limit.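

Compound 3 and compound 4 each give only a limit of the assay, not a number, and the step between them cannot be read. The compounds shown leave open whether cyclopropylamino and (4-hydroxyphenyl)amino differ at all in strength of inhibition.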